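Adding an Acetyl Group to Compound 3

The compounds below may be only part of what the source reports. "The series", "measured", "known", "first", "only" and "open" are said of these compounds alone.

Of the compounds shown here, three on a shared core have been measured. Compound 1 `C=C1CC[C@@H]2[C@](C)(COC(C)=O)[C@H](OC(C)=O)CC[C@@]2(C)[C@@H]1C/C=C1/C(=O)OC[C@H]1OC(C)=O` gives 10 uM in a functional assay on MCF7 cells (Homo sapiens) for cytotoxicity, read by sulforhodamine B assay; a higher number here means that more compound is needed for the effect, a lower number that less compound is needed. Compound 2 `C=C1CC[C@@H]2[C@](C)(CO)[C@H](OC(C)=O)CC[C@@]2(C)[C@@H]1C/C=C1/C(=O)OC[C@H]1OC(C)=O` gives 11 uM in this assay, and compound 3 `C=C1CC[C@@H]2[C@](C)(CO[Si](C)(C)C(C)(C)C)[C@H](O)CC[C@@]2(C)[C@@H]1C/C=C1/C(=O)OC[C@H]1O` gives 47 uM in this assay.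

Compounds 2 and 1 differ in one place: acetyl in place of hydrogen on an oxygen on a saturated carbon. That change made a 1.1-fold lower number from compound 2 to compound 1 (0.04 log units; within the scatter). Compound 3 stands apart from both: its number is the highest of the three, and the gaps to compound 2 and to compound 1 both lie beyond the scatter. The difference between the core of compound 3 and the core of compound 2 is not broken down here.

Compound 4 `C=C1CC[C@@H]2[C@](C)(CO[Si](C)(C)C(C)(C)C)[C@H](OC(C)=O)CC[C@@]2(C)[C@@H]1C/C=C1/C(=O)OC[C@H]1O` has not yet been measured in this assay. It differs from compound 3 in one place: acetyl in place of hydrogen on an oxygen on a saturated carbon. Among the measured compounds shown here, this is the same kind of change as the one from compound 2 to compound 1, but not the same: in the earlier pair the oxygen sits on a saturated carbon whose other neighbour is a saturated chain carbon, whereas in compound 4 the other neighbour is a saturated ring carbon.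

The expected step is a 1.2-fold lower number from compound 3 to compound 4 (0.07 log units; within the scatter), which rests on the earlier step from compound 2 to compound 1 being within the scatter. Compound 4 is therefore expected to give 40 uM in this assay. The estimate for compound 4 is expected to fall between 18 uM and 90 uM.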

Compound 4, concentration for half-maximal effect: 9.79 uM
Compound 4: the middle estimate sits 4.1-fold (0.61 log units) above what was measured, and the stated range ends above it.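

On the core of compound 3, acetyl in place of hydrogen on an oxygen on a saturated carbon gave a 4.8-fold lower number from compound 3 to compound 4 (0.68 log units; beyond the scatter) in this assay, whereas the same kind of change left compound 2 and compound 1 within the scatter of each other. Set side by side, the two steps show that this change does not carry a single size from one core to another in this series: the same change on two cores in this assay, a 1.1-fold lower number (0.04 log units; within the scatter) from compound 2 to compound 1 and a 4.8-fold lower number (0.68 log units; beyond the scatter) from compound 3 to compound 4, 4.4-fold (0.64 log units) apart, beyond the scatter of two such steps. Among the compounds shown here, they do not show what sets the two steps apart: there are only two pairs, the saturated carbon bearing the oxygen has a saturated chain carbon as its other neighbour in the first pair and a saturated ring carbon in the second, and the cores differ as well, so the place of the change and the rest of the core cannot be told apart.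

The compounds shown leave open whether a longer acyl chain, such as propionyl, or a benzoyl group on the same oxygen would follow the step seen with acetyl on the core of compound 3. They also leave open whether an amine in place of that oxygen would hold the number near that of compound 4, at 9.79 uM.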